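Series notes: replacing the nitrile on the shared core

The compounds below may be only part of what the source reports. "The series", "measured", "known", "first", "only" and "open" are said of these compounds alone.

Measured so far:
- compound 1 `Cc1nc2c(OCc3ccccc3)cccn2c1C#N`: 25%
- compound 2 `CSCc1c(C)nc2c(OCc3ccccc3)cccn12`: 29%
- compound 3 `CCCCC(=O)OCc1c(C)nc2c(OCc3ccccc3)cccn12`: 45%

All three share one core and differ only in the group on the aromatic carbon of the five-membered ring. In a functional assay on the whole organism with Rattus norvegicus as the target, with a stated time of 4 h, at a dose of 40 mg/kg by the intraperitoneal route (on this read-out higher numbers stand for more inhibition at the one dose given (going by the name of the read-out) and lower numbers for less inhibition), compound 1 gives 25%, the lowest of the three numbers; compound 2 sits closest, a number 4 percentage points higher from compound 1 to compound 2 (within the scatter), and compound 3 furthest, a number 20 percentage points higher from compound 1 to compound 3 (beyond the scatter). Between the two substituted methyl groups the step of a number 16 percentage points higher from compound 2 to compound 3 (beyond the scatter).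

Compound 4 `Cc1nc2c(OCc3ccccc3)cccn2c1COC(=O)N(C)C` is not yet measured. It differs from compound 1 by ((dimethylcarbamoyl)oxy)methyl in place of cyano on an aromatic carbon. Within the data shown here, two measured steps bear on it: the change to (methylsulfanyl)methyl, which stayed within the scatter, and the change to ((butylcarbonyl)oxy)methyl, which rose modestly beyond it. The entering group of compound 4 is, like that of compound 3, an oxymethyl group carrying a carbonyl, so the step toward compound 3 is taken as the nearer guide, tempered by the small step toward compound 2. In this assay compound 4 is therefore expected to show a number 12 percentage points higher from compound 1 to compound 4 (beyond the scatter), a modest rise. The estimate for compound 4 is 37%, within a range from 22% to 55%.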

Compound 4, a percentage reported as inhibition, in the whole organism at one dose (the size of the read-out at that dose, not a potency): 75%
For compound 4 the middle estimate is 38 percentage points below the measured one, outside the stated range (above it).
By their numbers in this assay, from the lowest: compounds 1 and 2 (each within the scatter of the next); then compound 3; then compound 4.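

In this assay, among these compounds, the group on this aromatic carbon turns out to carry far more of the read-out than the earlier compounds showed: ((dimethylcarbamoyl)oxy)methyl in place of cyano gives a number 50 percentage points higher from compound 1 to compound 4 (beyond the scatter), and (dimethylcarbamoyl)oxy in place of methylsulfanyl on the saturated chain carbon gives a number 46 percentage points higher from compound 2 to compound 4 (beyond the scatter). With the oxymethyl part kept, dimethylamino in place of butyl on the carbonyl carbon still gives a number 30 percentage points higher from compound 3 to compound 4 (beyond the scatter), so among these compounds the group on the carbonyl carbon matters and an oxymethyl group carrying a carbonyl does not by itself fix the number. No measurement at hand gives a reason for this rise.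

The compounds shown leave open whether the rise belongs to dimethylamino in particular or would persist with a plain amino group, a diethylamino group or a pyrrolidine ring on the carbonyl carbon. They also leave open how a methoxy group on that carbonyl would compare, and, with a single dose behind each number, how the order would look across a range of doses.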